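The compounds below may be only part of what the source reports. "The series", "measured", "known", "first", "only" and "open" are said of these compounds alone.

Among the compounds with values here, compound 2, whose structure is `COc1ccccc1C(=O)Nc1nnc(SCC(=O)Nc2ccc(C)cn2)s1`, is one of only two compounds on a shared core that have been tested so far. In a functional assay on HeLa cells (Homo sapiens) for antiproliferative activity, read by MTT assay, with a stated time of 48 h (a higher number here means a weaker inhibitor, a lower number a stronger inhibitor), compound 2 gives > 80000 nM, which is a limit of the assay rather than a number. Within the data shown here, its single measured neighbour is compound 1, with the structure `COc1ccccc1C(=O)Nc1nnc(SCC(=O)Nc2ccc(Br)cn2)s1`. In this assay compound 1 gives > 80000 nM, again a limit. Among the measured compounds shown here, the one measured step, a step that the two limits leave unreadable from compound 1 to compound 2, therefore cannot be read, because both of its ends rest at the same limit, as the limit of > 80000 nM in this assay, at which 2 of the 2 values shown sit, summarises.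

Compound 3, whose structure is `COc1ccccc1C(=O)Nc1nnc(SCC(=O)Nc2ccc(Cl)cn2)s1`, has not yet been measured. It differs from compound 2 by chloro in place of methyl on an aromatic carbon. For the measured compounds named here, no measured step bears on this exchange, since the only one, a step that the two limits leave unreadable from compound 1 to compound 2, is itself unreadable. The expectation for compound 3 is therefore no movement beyond the scatter in this assay, and the estimated step is a step that the limit leaves unreadable from compound 2 to compound 3. Compound 3 is expected to show about 100000 nM in this assay, within an estimated range from 30000 nM to 300000 nM, and the result is expected most probably to be reported as a limit once more.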

Compound 3, half-maximal inhibitory concentration: > 80000 nM
Compound 3: a limit, no number (the forecaster's own chance of this, stated with the estimate: 85%); the middle value does not contradict the limit.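

Compound 3 sits at the same assay limit as compound 1 and compound 2, so none of the steps among these three compounds can be read, and no size can be given for exchanging bromo, methyl or chloro: the limit of > 80000 nM in this assay, at which 3 of the 3 values shown sit.

The compounds shown leave open whether any change to the shared core would give a measurable value in this assay.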